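The compounds below may be only part of what the source reports. "The series", "measured", "known", "first", "only" and "open" are said of these compounds alone.

Measured so far:
compound 1 `O=C(O)c1cc(-c2ccc(-c3ccc(F)c(Cl)c3)cc2)n(-c2ccc(Cl)cc2Cl)n1` — 20900 nM
compound 2 `O=C(O)c1cc(-c2ccc(-c3ccc(Cl)cc3Cl)cc2)n(-c2ccccn2)n1` — > 100000 nM

Among the compounds with values here, in an assay on isolated protein for inhibition of methionine--tRNA ligase, cytoplasmic (Homo sapiens) (a higher number here means a weaker inhibitor, a lower number a stronger inhibitor), compound 1 gives 20900 nM, the only number in the set. For compound 2 the assay reports only a limit, > 100000 nM. That reading is the limit of > 100000 nM in this assay, at which 1 of the 2 values shown sits. Within the data shown here, compound 1 therefore stands as the sole compound with a measured value here. Compound 3 `O=C(O)c1cccc(-c2ccc(-c3cc(C(=O)O)nn3-c3ccc(Cl)cc3Cl)cc2)c1` awaits measurement in this assay; it differs from compound 1 thus: 3-carboxyphenyl in place of 3-chloro-4-fluorophenyl on an aromatic carbon. Among the measured compounds shown here, no step between measured compounds exists to size this change. The expected step, a 1.4-fold lower number from compound 1 to compound 3 (0.14 log units; within the scatter), is none beyond the scatter, with a wide range. For compound 3 the estimate is 15000 nM, expected between 3000 nM and 80000 nM.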

Compound 3, half-maximal inhibitory concentration: 40900 nM
Compound 3: the middle estimate sits 2.7-fold (0.44 log units) below what was measured; the range from low to high includes it.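

In this assay, within the data shown here, the swap at this position, on an aromatic carbon para to a large group, gives the first sized step: a 2.0-fold higher number from compound 1 to compound 3 (0.29 log units; within the scatter). The 3-carboxyphenyl ring, with a hydrogen-bond donor and acceptor, and the 3-chloro-4-fluorophenyl ring, with neither, therefore cannot be told apart here. Nothing shown gives a cause for this step.

Still open, as far as these compounds go, is whether an amine on this ring, or an unsubstituted phenyl ring, would move the reading beyond the scatter. Also open, from the compounds shown here alone, is whether a longer chain carrying the carboxylic acid would do so.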